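A few compounds are considered here, and "the series" means these few. Any claim that something is new, unique, unknown or untested is made for them only; others in the source may bear on it.

Working notes on the series in a functional assay on HFF cells (Homo sapiens) for inhibition; a higher number here means a weaker inhibitor, a lower number a stronger inhibitor.

Two compounds have been run. Compound 1, `Cc1nsc2c1nc(SCc1ccccc1)n2[C@@H]1O[C@H](CO)[C@@H](O)[C@@H]1O`, gives only a limit of the assay, > 100000 nM. Compound 2, `Cc1nsc2c1ncn2[C@@H]1O[C@H](CO)[C@@H](O)[C@H]1O`, gives 150000 nM. Among the measured compounds shown here, compound 2 thus holds the only measured number in the set; the other entry is a limit, (the limit of > 100000 nM in this assay, at which 1 of the 2 values shown sits), so no step between measured compounds can be drawn and no direction within the set has yet been established.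

The next compound, compound 3, is `Cc1nsc2c1nc(SCc1ccccc1)n2[C@@H]1O[C@H](CO)[C@@H](O)[C@H]1O`. Against compound 2 the change is benzylsulfanyl in place of hydrogen on an aromatic carbon. The group entering is benzylsulfanyl, on an aromatic carbon of the five-membered aromatic ring with two nitrogen atoms, between the two ring nitrogen atoms.

For the measured compounds named here, no measured step shows what this change does. Going by the values given here, the only guidance is that compound 2 sits at 150000 nM. Compound 1 reaches only a limit of the assay, > 100000 nM. Compound 3 is therefore expected to remain weak, with a step from compound 2 estimated as a 1.2-fold lower number from compound 2 to compound 3 (0.06 log units; within the scatter), not beyond the scatter in any direction. The estimate for compound 3 is 130000 nM, in a range from 40000 nM to 400000 nM, with a real chance that only a limit is reported.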

Compound 3, half-maximal inhibitory concentration: > 100000 nM
Compound 3 gave a limit, no number (the forecaster's own chance of this, stated with the estimate: 50%); the middle value is on the limit's open side.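

In this assay compound 3 gives only a limit of the assay, > 100000 nM, not a number, so neither the step from compound 2 nor the step from compound 1 can be read. The compounds shown leave open whether benzylsulfanyl in place of hydrogen on an aromatic carbon, or the difference in configuration between compound 1 and compound 3, changes inhibition at all.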